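Swapping the Amide Substituent on an Inactive Core

The source may report more compounds than this note shows. Statements on the series, on what has been measured and on what is new or still open speak of the compounds shown alone.

In a functional assay on SW480 cells (Homo sapiens) for cytotoxicity, read by MTT assay, with a stated time of 24 h (on this read-out lower numbers stand for stronger inhibition and higher numbers for weaker inhibition), compound 1, with structure `C=CC1=C(C(=O)NC(C)(C)C)C(c2ccc(OC)cc2)OC1`, gives > 100000 nM, which is a limit of the measurement rather than a number. Compound 2, with structure `C=CC1=C(C(=O)O)C(c2ccc(F)cc2)OC1`, likewise gives only a limit, > 100000 nM. Compound 3, with structure `C=CC1=C(C(=O)NC(C)(C)C)C(c2ccc(F)cc2)OC1`, also sits at a limit, > 100000 nM. All three values shown sit at the limit of > 100000 nM in this assay, at which 3 of the 3 values shown sit, so compound 1 stands on the same footing as its neighbours, without a number of its own. Compound 4, with structure `C=CC1=C(C(=O)NCc2ccccc2F)C(c2ccc(OC)cc2)OC1`, differs from compound 1 by 2-fluorobenzyl in place of tert-butyl on an amide-type nitrogen. Two measured steps could be compared: a step that the two limits leave unreadable from compound 1 to compound 3, and a step that the two limits leave unreadable from compound 2 to compound 3, the only one that alters the amide; each joins two limits and gives no readable size. Within the data shown here, no measured step therefore tells how far the change from tert-butyl to 2-fluorobenzyl should move this assay, and the expectation is that compound 4 will most likely remain at the limit, a step that the limit leaves unreadable from compound 1 to compound 4. Compound 4 is estimated at 150000 nM, within a range from 40000 nM to 500000 nM.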

Compound 4, half-maximal inhibitory concentration: > 100000 nM
Compound 4: no number, only a limit (the forecaster's own chance of this, stated with the estimate: 70%); the middle value is on the limit's open side.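

Among these compounds, compound 1 and compound 4 both end at a limit rather than a number, so putting 2-fluorobenzyl in place of tert-butyl gives no step whose size can be read: the limit of > 100000 nM in this assay, at which 4 of the 4 values shown sit. The compounds shown leave open which change to the shared core, if any, would give a measurable value in this assay.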